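Swapping the aryl amide on a weakly active scaffold

The source may hold more compounds than are shown below. What is called first, only, known or untested is meant among the compounds shown, and "the series" means these compounds.

Of the compounds shown here, two sharing one core have been measured in a functional assay on HL-60 cells (Homo sapiens) for antiproliferative activity, with a stated time of 24 h; on this read-out lower numbers stand for stronger inhibition and higher numbers for weaker inhibition. Compound 1, `NC(=O)c1c(NC(=O)c2ccc(C(F)(F)F)cc2)sc2c1CCN(Cc1ccc(Cl)cc1Cl)C2`, carries a 4-(trifluoromethyl)phenyl amide, and in this assay compound 1 gives 14900 nM. Compound 2, `NC(=O)c1c(NC(=O)c2ccccc2F)sc2c1CCN(C(=O)Nc1ccccc1Cl)C2`, carries a 2-fluorophenyl amide instead and a different group on the ring nitrogen; in this assay compound 2 gives 32700 nM. Compound 2 therefore stands at the higher, weaker end of the two numbers, and its gap to compound 1 lies beyond the usual scatter. Compound 3, `NC(=O)c1c(NC(=O)c2ccc(C(F)(F)F)cc2)sc2c1CCN(C(=O)Nc1ccccc1Cl)C2`, keeps the ring-nitrogen group of compound 2 and changes only the amide: 4-(trifluoromethyl)phenyl in place of 2-fluorophenyl on a carbonyl carbon. Going by the values given here, no measured pair isolates this single change, since compound 1 and compound 2 differ in two places at once. Given that both measured numbers are weak, the step from compound 2 to compound 3 is expected to be small, a 1.5-fold lower number from compound 2 to compound 3 (0.17 log units; within the scatter), probably towards a slightly lower number but possibly not beyond the scatter. Compound 3 is therefore estimated at 22000 nM, with a plausible range from 8000 nM to 60000 nM.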

Compound 3, half-maximal inhibitory concentration: > 50000 nM
Compound 3: a limit, no number; the forecaster's own chance of this, stated with the estimate: 20%; at least 2.2-fold (0.35 log units) between middle value and limit.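

In this assay compound 3 gives > 50000 nM, which is a limit of the assay and not a number. Going by these compounds alone, this pair isolates the amide change for the first time, and 4-(trifluoromethyl)phenyl in place of 2-fluorophenyl on a carbonyl carbon gives an at least 1.5-fold higher number from compound 2 to compound 3 (0.18 log units; that floor lies within the scatter), which shows no gain from the swap, although its true size cannot be read and its floor does not establish a real loss, because compound 3 sits at the limit: the limit of > 50000 nM in this assay, at which 1 of the 3 values shown sits. With the 4-(trifluoromethyl)phenyl amide held fixed, (2-chlorophenyl)carbamoyl in place of 2,4-dichlorobenzyl on the ring nitrogen gives an at least 3.3-fold higher number from compound 1 to compound 3 (0.52 log units; beyond the scatter), so this single change clearly separates two compounds on the shared core.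

From the compounds shown here alone, it remains open how the 2-fluorophenyl amide behaves with 2,4-dichlorobenzyl on the ring nitrogen, so it cannot be told whether the two changes act independently. Also open, going by these compounds, is whether an aryl amide carrying an amine or a carboxylic acid in place of trifluoromethyl or fluorine would give a lower number in this assay.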